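This account rests on a few compounds, and the source may have more. Where it says the series, first, only, none or still open, it means among the compounds named here.

Working notes on the series. In an ADME assay on HFF cells (Homo sapiens) for cytotoxicity, with a stated time of 8 days (on this read-out higher numbers stand for lower toxicity in this test and lower numbers for higher toxicity in this test), compound 3 `CC(C)CNc1nc(N)nc2c1ncn2/C=C1/CC1(CO)CO` gives > 300000 nM, which is a limit and not a number. Compound 1 `COCCOc1nc(N)nc2c1ncn2/C=C1/CC1(CO)CO` gives > 300000 nM, also a limit. Compound 2 `Nc1nc(NC2CCCCC2)c2ncn(/C=C3/CC3(CO)CO)c2n1` gives > 300000 nM, again a limit. The whole set therefore stands at one point: the limit of > 300000 nM in this assay, at which 3 of the 3 values shown sit.

The next compound is compound 4 `CCCCCOc1nc(N)nc2c1ncn2/C=C1/CC1(CO)CO`, with pentyloxy in place of isobutylamino on an aromatic carbon.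

Among the measured compounds shown here, three measured steps bear on this change, and none has a size that can be read. The closest is a step that the two limits leave unreadable from compound 1 to compound 3, with isobutylamino in place of 2-methoxyethoxy on the same aromatic carbon. The others are a step that the two limits leave unreadable from compound 1 to compound 2 and a step that the two limits leave unreadable from compound 2 to compound 3. These steps show no change in this assay at this carbon, though the shared limit could hide one. No step beyond the scatter is therefore expected, and compound 4 will probably report the same limit. The expected step is a number no higher from compound 3 to compound 4 (the limit leaves the size open). For compound 4 the estimated value is 300000 nM, with an expected range from 100000 nM to 300000 nM.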

Compound 4, half-maximal cytotoxic concentration: 259000 nM
Beside the measured number, compound 4's estimate is 1.2-fold (0.06 log units) above it; measured number inside the range.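

Among the compounds shown here, compound 4 gives the first number in this assay rather than a limit, with pentyloxy on this aromatic carbon. Set against the other compounds, the change reads as an at least 1.1-fold lower number from compound 3 to compound 4 (0.06 log units; that floor lies within the scatter) and as an at least 1.1-fold lower number from compound 2 to compound 4 (0.06 log units; that floor lies within the scatter) and as an at least 1.1-fold lower number from compound 1 to compound 4 (0.06 log units; that floor lies within the scatter) with every one of these floors within the scatter, so no real change at this position is shown. The true sizes of these steps stay unreadable, since the other compounds all remain at a limit: the limit of > 300000 nM in this assay, at which 3 of the 4 values shown sit.

On these data alone, it remains open whether a longer chain such as octyloxy on this aromatic carbon would move the read-out beyond the scatter. As far as these compounds go, it also remains open whether a carboxylic acid at the end of the pentyloxy chain would do so.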